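The compounds below may be only part of what the source reports. "The series", "measured", "known", "first", "only" and "open" are said of these compounds alone.

Three compounds were measured in a functional assay on MKN-74 cells (Homo sapiens) for antiproliferative activity, with a stated time of 24 h; on this read-out higher numbers stand for weaker inhibition and lower numbers for stronger inhibition:

compound 1, `NC(=O)c1c(NC(=O)c2ccc(C(F)(F)F)cc2)sc2c1CCN(C(=O)Nc1ccccc1Cl)C2`, 43900 nM
compound 2, `Cc1ccc(C(=O)Nc2sc3c(c2C(N)=O)CCN(C(=O)Nc2ccccc2Cl)C3)cc1`, 27600 nM
compound 3, `Cc1ccccc1C(=O)Nc1sc2c(c1C(N)=O)CCN(C(=S)Nc1ccccc1C(F)(F)F)C2`, 17400 nM

Compound 1 and compound 2 differ in one place, (methyl in place of trifluoromethyl on an aromatic carbon). This change brought a 1.6-fold lower number from compound 1 to compound 2 (0.20 log units; within the scatter).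

Compound 3 carries a different core; how it differs from compound 1 is not broken down here. Its value lies below that of compound 1 by more than the usual scatter, while against compound 2 the two values fall within the scatter of each other.

Compound 4, `Cc1ccccc1NC(=S)N1CCc2c(sc(NC(=O)c3ccccc3C)c2C(N)=O)C1`, is not yet measured. It differs from compound 3 in one place: methyl in place of trifluoromethyl on an aromatic carbon. This is the same kind of change as that from compound 1 to compound 2, though the place is not the same: there the methyl sits para to a large group, here ortho to a large group, and on another ring of the molecule.

Because the earlier step of a 1.6-fold lower number from compound 1 to compound 2 (0.20 log units; within the scatter) stayed within the scatter, the step from compound 3 to compound 4 is expected to be small as well, about a 1.2-fold lower number from compound 3 to compound 4 (0.09 log units; within the scatter). Compound 4 is therefore estimated to give 14000 nM, with a likely range from 6000 nM to 35000 nM.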

Compound 4, half-maximal inhibitory concentration: > 50000 nM
Compound 4 was reported as a limit; the forecaster's own chance of this, stated with the estimate: 15%; middle value at least 3.5-fold (0.55 log units) from the limit.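

In this assay compound 4 gives > 50000 nM, which is a limit of the assay and not a number. Methyl in place of trifluoromethyl brought an at least 2.8-fold higher number from compound 3 to compound 4 (0.45 log units; beyond the scatter), so the result of this change on one core did not carry over to the other, and the two steps differ: the same change on two cores in this assay, a 1.6-fold lower number (0.20 log units; within the scatter) from compound 1 to compound 2 and an at least 2.8-fold higher number (0.45 log units; beyond the scatter) from compound 3 to compound 4, at least 4.5-fold (0.65 log units) apart, beyond the scatter of two such steps This shows that the step seen on the first pair cannot be taken as a guide for the second, but it does not show whether the core or the ring bearing the change accounts for the gap, and the full size of the new step stays unknown, as the value for compound 4 is only a limit: the limit of > 50000 nM in this assay, at which 1 of the 4 values shown sits.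

The compounds shown leave open how a methoxy group, a nitrile or an amine would fare in the place of the trifluoromethyl on the core of compound 3. They also leave open whether the same change, made on the same ring in both cores, would give steps that agree.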